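The source may hold more compounds than are shown below. What is called first, only, known or untested is meant among the compounds shown, and "the series" means these compounds.

The measured compounds:

Compound 1, `Nc1nc(NC2CCCCC2)c2ncn(/C=C3/CC3(CO)CO)c2n1`, in an ADME assay on BCBL1 cells (Homo sapiens) for cytotoxicity, with a stated time of 7 days (on this read-out lower numbers stand for higher toxicity in this test and higher numbers for lower toxicity in this test), gives > 20000 nM, a limit of the assay and not a number.
Compound 2, `CC(C)CNc1nc(N)nc2c1ncn2/C=C1/CC1(CO)CO`, gives > 20000 nM, again a limit of the assay.
Compound 3, `Nc1nc(OCC(F)(F)F)c2ncn(/C=C3/CC3(CO)CO)c2n1`, gives > 20000 nM, also a limit of the assay.

Compound 1 thus has no measured number in this assay, only a limit, and the two other compounds sit at the same limit (the limit of > 20000 nM in this assay, at which 3 of the 3 values shown sit). Changing the cyclohexyl on the ring nitrogen to isobutyl, a step that the two limits leave unreadable from compound 1 to compound 2, and changing the cyclohexylamino on the aromatic carbon to 2,2,2-trifluoroethoxy, a step that the two limits leave unreadable from compound 1 to compound 3, both give steps whose size cannot be read, since each starts and ends at the limit.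

Compound 4, `COCCOc1nc(N)nc2c1ncn2/C=C1/CC1(CO)CO`, has not been measured. It differs from compound 1 in one place: 2-methoxyethoxy in place of cyclohexylamino on an aromatic carbon. The closest measured comparison is the step to compound 3, where an alkoxy group likewise replaces the cyclohexylamino on the aromatic carbon and the result stays at the limit. Among the measured compounds shown here, no measured step points in either direction, so no step beyond the scatter is expected; compound 4 is expected to stay at the limit as well. The expected step is a step that the limit leaves unreadable from compound 1 to compound 4.

Compound 4 is therefore estimated at 30000 nM, with a range from 15000 nM to 100000 nM.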

Compound 4, half-maximal cytotoxic concentration: > 20000 nM
Compound 4: a limit, no number; the forecaster's own chance of this, stated with the estimate: 85%; the middle value lies beyond the limit too.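

In this assay compound 4 gives > 20000 nM, a limit and not a number. Its steps to compound 1, compound 2 and compound 3 therefore cannot be read: the limit of > 20000 nM in this assay, at which 4 of the 4 values shown sit. The compounds shown leave open whether any of these groups on the aromatic carbon changes the half-maximal cytotoxic concentration at all.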